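Replacing a cyclopentyl amide with a larger ring-bearing group

The compounds below may be only part of what the source reports. "The series", "measured", "known", "first", "only" and "open" are said of these compounds alone.

Of the compounds shown here, two have been measured in a functional assay on LoVo cells (Homo sapiens) for antiproliferative activity, read by MTT assay, with a stated time of 72 h; on this read-out lower numbers stand for stronger inhibition and higher numbers for weaker inhibition. Compound 1 `Cn1cc(-c2nn(Cc3ccc(C(=O)NC4CCCC4)cc3)c(=O)c3ccccc23)cn1` gives 23700 nM in this assay, the lowest of the two numbers. Compound 2 `O=C(Nc1ccccc1Cl)c1ccc(Nc2nn(Cc3ccc(C(=O)NC4CCCCC4)cc3)c(=O)c3ccccc23)cc1` gives 79500 nM in this assay, a higher number than that of compound 1, and the gap between the two lies beyond the usual scatter. For the measured compounds named here, the two structures differ in several places at once, so no single step between them can be drawn.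

Compound 3 `Cn1cc(-c2nn(Cc3ccc(C(=O)NC4CC(C)(C)N([O])C(C)(C)C4)cc3)c(=O)c3ccccc23)cn1` is not yet measured. It differs from compound 1 by a group of 11 heavy atoms (9 carbon, 1 nitrogen, 1 oxygen; one six-membered non-aromatic ring with 1 hetero atom) in place of a group of 5 heavy atoms (5 carbon; one five-membered non-aromatic ring of carbon only), on an amide-type nitrogen. Going by the values given here, no measured pair shows the effect of this change, so the expectation rests on compound 1 alone. Compound 3 is expected to stay close to compound 1, with a step from compound 1 to compound 3 of a 1.1-fold lower number from compound 1 to compound 3 (0.03 log units; within the scatter), not clearly beyond the scatter in either direction. The estimate for compound 3 in this assay is 22000 nM, within a range from 6000 nM to 80000 nM.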

Compound 3, half-maximal inhibitory concentration: 50100 nM
The estimate for compound 3 lay 2.3-fold (0.36 log units) below the measured number, and the stated range covers the measured number.
By their numbers in this assay, from the lowest: compound 1; then compounds 3 and 2 (each within the scatter of the next).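

On the amide-type nitrogen, putting the six-membered ring with 1 hetero atom in place of cyclopentyl gives in this assay a 2.1-fold higher number from compound 1 to compound 3 (0.33 log units; beyond the scatter) and so moves the number modestly towards weaker inhibition. For the compounds shown here, this is the only single change that can be read here, as the earlier compounds differ in several places at once. It shows that this position can carry a group of 11 heavy atoms with only this limited shift, and no measurement at hand accounts for the step.

Going by these compounds, whether the step follows the size of the group or its hetero atom stays open. A plain piperidinyl or tetrahydropyranyl ring on the same amide nitrogen of the core of compound 1 would bear on that question.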